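Dropping the acid from a chemokine receptor antagonist

The source may report more compounds than this note shows. Statements on the series, on what has been measured and on what is new or still open speak of the compounds shown alone.

Compound 1 `C[C@@H]1CN(c2sc(C(F)(F)F)nc2-c2nc3ccccc3[nH]2)CCN1C(=O)Cn1ccc(C(=O)O)n1` gives the highest number of the two measured values in a functional assay on CHO-K1 cells for antagonist activity at C-X-C chemokine receptor type 3 (Homo sapiens), read by FLIPR, with a stated time of 10 min, in the presence of a further agent that is not named here (a lower number here means a stronger inhibitor, a higher number a weaker inhibitor), namely 2100 nM; compound 2 `COC1CCN(CC(=O)N2CCN(c3sc(C(F)(F)F)nc3-c3nc4ccccc4[nH]3)C[C@H]2C)C1` gives 42 nM in this assay. The step of a 50-fold lower number from compound 1 to compound 2 (1.70 log units; beyond the scatter) replaced the whole acid-bearing pyrazole group. Compound 3 `C[C@@H]1CN(c2sc(C(F)(F)F)nc2-c2nc3ccccc3[nH]2)CCN1C(=O)Cn1cccn1` keeps that pyrazole and changes only (hydrogen in place of carboxy on an aromatic carbon), hydrogen in place of carboxy on an aromatic carbon. Among the measured compounds shown here, no measured step removes the carboxy alone, so the only guide is the large improving step a 50-fold lower number from compound 1 to compound 2 (1.70 log units; beyond the scatter), which removed the acid among other changes. Compound 3 is therefore expected to improve by a 5.3-fold lower number from compound 1 to compound 3 (0.72 log units; beyond the scatter), to an estimated 400 nM with a range of 100 nM to 2000 nM.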

Compound 3, half-maximal inhibitory concentration: 13 nM
Compound 3: middle estimate off by 31-fold (1.49 log units), on the high side; measured number below the stated range.
By their numbers in this assay, from the lowest: compound 3; then compound 2; then compound 1.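

In this assay, removing only the carboxy from the aromatic carbon of the pyrazole gives a 160-fold lower number from compound 1 to compound 3 (2.21 log units; beyond the scatter), so this single change is enough for a large gain, without the new 3-methoxypyrrolidin-1-yl group. The unsubstituted 1H-pyrazol-1-yl group also improves on that pyrrolidine, with a 3.2-fold lower number from compound 2 to compound 3 (0.51 log units; beyond the scatter). Nothing measured here explains either step.

As far as these compounds go, whether a methyl ester or an amine on that same aromatic carbon would give a number closer to compound 1 or to compound 3 remains open.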